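Rearranging the Side Chain of Compound 1

The source may report more compounds than this note shows. Statements on the series, on what has been measured and on what is new or still open speak of the compounds shown alone.

Compound 1 `CCCC(=O)OCSc1ccccc1C(=O)NCCCNC(C)=O` was tested in an ADME assay on CEM-SS cells (Homo sapiens) for cytotoxicity, read by XTT assay, with a stated time of 6 days (on this read-out higher numbers stand for lower toxicity in this test and lower numbers for higher toxicity in this test), where compound 1 gives 21.1 uM. Among the three compounds measured, this is the highest number. Compound 3 `CCCC(=O)OC[Se]c1ccccc1C(=O)NCCC(N)=O` gives 10.5 uM, a gap from compound 1 that lies within the scatter, while compound 2 `CCCC(=O)OC[Se]c1ccccc1C(=O)NCC(N)=O` gives 6.8 uM, a gap that lies beyond it. Compounds 2 and 3 share a related core and differ from each other only in the length of the side chain: a 1.5-fold higher number from compound 2 to compound 3 (0.19 log units; within the scatter). Compound 4 `CCCC(=O)OCSc1ccccc1C(=O)NCC(=O)NC(C)C` has not yet been measured. It holds the same atoms as compound 1 but joined differently: isopropylcarbamoyl in place of 2-acetamidoethyl on a saturated chain carbon bound to an amide-type nitrogen. Going by the values given here, no measured step covers this exact rearrangement. Among the compounds with values here, the only step available, from compound 2 to compound 3, shifts the amide end along the chain and stays within the scatter, so a rearrangement of the same atoms is expected to change little as well: a 1.2-fold lower number from compound 1 to compound 4 (0.07 log units; within the scatter). Compound 4 is therefore estimated at 18 uM, with a range from 8 uM to 45 uM.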

Compound 4, half-maximal toxic concentration: 92 uM
Estimate against measurement, compound 4: 5.1-fold (0.71 log units) below, outside the stated range (above it).
By their numbers in this assay, from the lowest: compounds 2, 3 and 1 (each within the scatter of the next, the first and the last beyond it); then compound 4.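

In this assay the exchange of 2-acetamidoethyl for isopropylcarbamoyl gives a 4.4-fold higher number from compound 1 to compound 4 (0.64 log units; beyond the scatter) on a saturated chain carbon bound to an amide-type nitrogen, so here the way the atoms are joined matters, not just which atoms are present. Going by these compounds alone, the two groups have the same count of heavy atoms, hydrogen-bond donors and hydrogen-bond acceptors, whereas the only earlier step, a 1.5-fold higher number from compound 2 to compound 3 (0.19 log units; within the scatter), gave no sign that changes in this part of the molecule could move the number beyond the scatter. Nothing measured here accounts for the higher number of the rearranged compound.

From the compounds shown here alone, it remains open whether the isopropyl end itself or the new order of the chain carries the effect. A tert-butyl group, a longer chain or a terminal carboxylic acid in this place could help separate those two readings.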